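The source may hold more compounds than are shown below. What is called first, only, known or untested is meant among the compounds shown, and "the series" means these compounds.

Measured so far:
compound 1, `ClCc1cccc(Cn2cnc3ncnc(Cl)c32)c1`: 1690 nM
compound 2, `ClCc1ccccc1Cn1cnc2ncnc(Cl)c21`: 2230 nM

Two compounds have a number. In a functional assay on HCC 2998 cells (Homo sapiens) for cytotoxicity, read by sulforhodamine B assay, with a stated time of 48 h (a higher number here means a weaker inhibitor of growth, a lower number a stronger inhibitor of growth), compound 1 gives 1690 nM, and in this assay compound 2 gives 2230 nM. Compound 1 holds the lower of the two numbers, but the gap to compound 2 is within the usual scatter, so the two count as alike rather than as a real difference.

Compound 3 `ClCc1cccc(Cn2cnc3nc(Cl)nc(Cl)c32)c1` differs from compound 1 in one place: chloro in place of hydrogen on an aromatic carbon. For the measured compounds named here, no measured pair shows a step of this kind, so the numbers at hand give no direction for it. The step is therefore expected to be small, estimated as a 1.2-fold lower number from compound 1 to compound 3 (0.08 log units; within the scatter), and not clearly beyond the scatter in either direction. On that basis compound 3 is expected to give 1400 nM in this assay, with a range from 500 nM to 4000 nM.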

Compound 3, concentration for 50% growth inhibition: 1900 nM
Compound 3: the middle estimate sits 1.4-fold (0.13 log units) below what was measured; the measured number falls inside the stated range.
By their numbers in this assay, from the lowest: compounds 1, 3 and 2 (each within the scatter of the next).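

In this assay, putting a chloro group in place of hydrogen on the aromatic carbon between two ring nitrogen atoms gives a 1.1-fold higher number from compound 1 to compound 3 (0.05 log units; within the scatter). For the compounds shown here, this is the first reading at this position, and it shows that one added chlorine atom here leaves growth inhibition without a clear change, so compound 1 and compound 3 count as alike. Nothing measured here explains why this change makes so little difference.

As far as these compounds go, it remains open whether a different group on this same carbon, such as an amine, a methoxy group or a longer chain, would also leave the number in place. This single pair also cannot say whether the same chloro step would behave alike in compound 2, where the chloromethyl group sits elsewhere on the benzene ring.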